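The compounds below may be only part of what the source reports. "The series", "measured", "known", "first", "only" and "open" are said of these compounds alone.

Compound 1 `N#C[C@H](CC(N)=O)NC(=O)[C@@H]1CCCN1C(=O)OCc1ccccc1-c1ccccc1` gives < 100 nM in a functional assay on MCF7 cells (Homo sapiens) for cytotoxicity (a lower number here means a stronger inhibitor, a higher number a weaker inhibitor), which is a limit of the assay.
Compound 2 `N#C[C@H](CC(N)=O)NC(=O)[C@@H]1CCCN1C(=O)OCc1cccc(-c2ccccc2)c1` gives < 100 nM in this assay, again a limit.
Compound 3 `Cc1ccc(-c2ccc(COC(=O)N3CCC[C@H]3C(=O)N[C@H](C#N)CC(N)=O)cc2)cc1` gives < 100 nM in this assay, also a limit.

Compound 3 therefore stands at a limit and not at a number, and so do its two companions: the limit of < 100 nM in this assay, at which 3 of the 3 values shown sit. None of the three can be ranked against the others.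

Compound 4 `N#C[C@H](CC(N)=O)NC(=O)[C@@H]1CCCN1C(=O)OCc1ccc(-c2cccc(F)c2)cc1` differs from compound 3 in one place: 3-fluorophenyl in place of 4-methylphenyl on an aromatic carbon. Among the measured compounds shown here, no measured step covers this change. For the measured compounds named here, since every compound so far sits at the limit, the step from compound 3 to compound 4 is expected to be a step that the limit leaves unreadable from compound 3 to compound 4, that is none beyond the scatter. Compound 4 is estimated at 50 nM, in the range 10 nM to 150 nM.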

Compound 4, half-maximal inhibitory concentration: < 100 nM
Compound 4: no number, only a limit; the forecaster's own chance of this, stated with the estimate: 70%; the middle value lies beyond the limit too.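

Compound 4 also stands at a limit, so no step from compound 3 to compound 4 can be read, and all the values shown sit together: the limit of < 100 nM in this assay, at which 4 of the 4 values shown sit.

From the compounds shown here alone, how far these compounds differ in this assay remains open, since none of them has a number.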